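The source may hold more compounds than are shown below. What is called first, only, known or untested is meant among the compounds shown, and "the series" means these compounds.

Measured in a functional assay on CHO cells for antagonist activity at sphingosine 1-phosphate receptor 2 (Homo sapiens), read by calcium flux; a lower number here means a stronger inhibitor, a higher number a weaker inhibitor:
compound 1 `CCOc1cc2[nH]c(Cc3nn(CC(=O)N4CCOCC4)c(=O)c4ccccc34)nc2cc1Cl` gives 10 nM
compound 2 `O=C(O)Cn1nc(Cc2cn3cc(OCC4CC4)c(Cl)cc3n2)c2ccccc2c1=O` gives 9 nM

The two numbers lie within the usual scatter of each other, so compound 1 does not stand apart from compound 2 in this assay. Compound 3 `CCOc1cc2[nH]c(Cc3nn(CC(=O)O)c(=O)c4ccccc34)nc2cc1Cl` is not yet measured; it is drawn from compound 1 by hydroxy in place of morpholin-4-yl on a carbonyl carbon. Compound 2 already carries the carboxymethyl group on a different core and gives 9 nM in this assay, so the acid form is not expected to cost potency. The step expected from compound 1 is a 1.3-fold lower number from compound 1 to compound 3 (0.10 log units; within the scatter), none beyond the scatter. Compound 3 is estimated at 8 nM, in the range 2.5 nM to 25 nM.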

Compound 3, half-maximal inhibitory concentration in the sphingosine 1-phosphate receptor 2 assay: 17 nM
Compound 3: the middle estimate sits 2.1-fold (0.33 log units) below what was measured; measured number inside the range.
By their numbers in the sphingosine 1-phosphate receptor 2 assay, from the lowest: compounds 2, 1 and 3 (each within the scatter of the next).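

On the core of compound 1, hydroxy in place of morpholin-4-yl on a carbonyl carbon leaves potency within the scatter in the sphingosine 1-phosphate receptor 2 assay (a 1.7-fold higher number from compound 1 to compound 3 (0.23 log units; within the scatter)). In a physicochemical assay for lipophilicity, at pH 7.4 (a lower number here means a more polar compound, a higher number a more lipophilic compound), compound 1 gives 3.32 and compound 3 gives 1.8 (a number 1.52 log units lower from compound 1 to compound 3 (beyond the scatter)). For this pair, the distribution coefficient therefore moves far at this place while the inhibitory number does not move beyond the scatter.

Open, on these data alone, is whether a primary amide, a dimethylamide or a methyl ester on the same carbonyl carbon would fall between these two compounds in both read-outs. As far as these compounds go, a longer chain carrying the carboxy group is also open.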